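The source may report more compounds than this note shows. Statements on the series, on what has been measured and on what is new or still open speak of the compounds shown alone.

Of the compounds shown here, three have been measured: compound 1, `CCCCCCC(C)C(=O)NCC(C)(C)CC1=C(O)C(=O)c2ccccc2C1=O`, gives 23700 nM in a functional assay on KB cells (Homo sapiens) for cytotoxicity, read by resazurin assay, with a stated time of 3 days; a higher number here means a weaker inhibitor, a lower number a stronger inhibitor; compound 2, `CCCCCCCCC(=O)NCC(C)(C)CC1=C(O)C(=O)c2ccccc2C1=O`, gives 19700 nM; compound 3, `CCCCCCC(C)C(=O)OCC(C)(C)CC1=C(O)C(=O)c2ccccc2C1=O`, gives 16800 nM.

Compound 4, `CCCCCCCCC(=O)OCC(C)(C)CC1=C(O)C(=O)c2ccccc2C1=O`, has not yet been measured. It differs from compound 3 by one change: octyl in place of 1-methylheptyl on a carbonyl carbon. The same kind of change separates compound 1 from compound 2: octyl in place of 1-methylheptyl on a carbonyl carbon. The surroundings are not identical, though: in compound 1 the carbonyl carbon carries an amide-type nitrogen, in compound 3 an oxygen next to a carbonyl group. How the core of compound 1 and the core of compound 3 differ is not broken down here. The change gave a 1.2-fold lower number from compound 1 to compound 2 (0.08 log units; within the scatter) in this assay. A comparable, small step is therefore expected here, a 1.2-fold lower number from compound 3 to compound 4 (0.08 log units; within the scatter), resting on compound 3 and the step seen from compound 1. Compound 4 is estimated at 14000 nM.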

Compound 4, half-maximal inhibitory concentration: 38700 nM
Estimate against measurement, compound 4: 2.8-fold (0.44 log units) below, and the stated range ends below it.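

In this assay putting octyl in place of 1-methylheptyl gives a 2.3-fold higher number from compound 3 to compound 4 (0.36 log units; beyond the scatter) on the core of compound 3. This change therefore does not carry over with the same size and direction between these two cores: the same change on two cores in this assay, a 1.2-fold lower number (0.08 log units; within the scatter) from compound 1 to compound 2 and a 2.3-fold higher number (0.36 log units; beyond the scatter) from compound 3 to compound 4, 2.8-fold (0.44 log units) apart, beyond the scatter of two such steps. Going by these compounds alone, with only one pair on each core, this does not show why the two steps differ or how the change would behave on any other core.

The compounds shown leave open whether a longer chain such as decyl would follow either step. They also leave open what a chain ending in a carboxylic acid or an amine would do on these cores.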